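Testing One Amine Substituent Change on a Second Core

The source may hold more compounds than are shown below. What is called first, only, known or untested is meant among the compounds shown, and "the series" means these compounds.

Three compounds have so far been measured in an assay on membranes from striatum (strain Sprague-Dawley) for displacement of a labelled ligand from sodium-dependent dopamine transporter (Rattus norvegicus), read by scintillation counting, with a stated time of 120 min; a higher number here means a weaker inhibitor, a lower number a stronger inhibitor:

Compound 1, `CC(C)(C)CN1CCC(NCCSC(c2ccc(F)cc2)c2ccc(F)cc2)CC1`, gives 279 nM.
Compound 2, `CC(C)(C)CN1CCC(NCC[S+]([O-])C(c2ccc(F)cc2)c2ccc(F)cc2)CC1`, gives 431 nM.
Compound 3, `O=C(c1ccccc1F)N1CCC(NCCSC(c2ccc(F)cc2)c2ccc(F)cc2)CC1`, gives 46.1 nM.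

Compound 1 and compound 3 share a core and differ in a single place: (2-fluorophenyl)carbonyl in place of neopentyl on an amine nitrogen in a ring. That one change produced a 6.1-fold lower number from compound 1 to compound 3 (0.78 log units; beyond the scatter), a step that lies beyond the usual scatter of this assay and so counts as a real gain in binding.

Compound 2 is built on a different core from compound 1; how the two cores differ is not broken down here. In this assay compound 2 and compound 1 give numbers that sit within the scatter of each other, so the two cores cannot be told apart on the data at hand.

The unmeasured compound 4, `O=C(c1ccccc1F)N1CCC(NCC[S+]([O-])C(c2ccc(F)cc2)c2ccc(F)cc2)CC1`, stands to compound 2 exactly as compound 3 stands to compound 1: (2-fluorophenyl)carbonyl in place of neopentyl on an amine nitrogen in a ring. The place of the change is the same in both pairs, so this is the same change carried onto the second core.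

The expectation is that the change repeats its earlier effect, giving an estimated 5.7-fold lower number from compound 2 to compound 4 (0.76 log units; beyond the scatter), since the same change gave a 6.1-fold lower number from compound 1 to compound 3 (0.78 log units; beyond the scatter) and compound 2 starts from a value close to that of compound 1. Compound 4 is therefore expected to reach about 75 nM in this assay, with a likely range from 30 nM to 190 nM.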

Compound 4, inhibition constant: 604 nM
Estimate against measurement, compound 4: 8.1-fold (0.91 log units) below, and the stated range ends below it.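

Carried onto the core of compound 2, the swap of neopentyl for (2-fluorophenyl)carbonyl gives a 1.4-fold higher number from compound 2 to compound 4 (0.15 log units; within the scatter), so in this assay this pair cannot be told apart. The change therefore does not carry its effect from one core to the other, and the two steps differ by more than the scatter allows: the same change on two cores in this assay, a 6.1-fold lower number (0.78 log units; beyond the scatter) from compound 1 to compound 3 and a 1.4-fold higher number (0.15 log units; within the scatter) from compound 2 to compound 4, 8.5-fold (0.93 log units) apart, beyond the scatter of two such steps. Among these compounds, this shows that, for these four compounds, the result of the change depends on the core it sits on, but it rests on only two pairs in a single assay, so it does not show which feature of the cores matters or why the gain on the first core is absent on the second.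

The compounds shown leave open whether other groups on the same ring nitrogen, such as a plain benzyl or a benzoyl without fluorine, would also behave differently on the two cores. From the compounds shown here alone, it also remains open whether a third core would follow compound 1 and compound 3, with a real gain from the change, or compound 2 and compound 4, with none that can be told from the scatter.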